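The compounds below may be only part of what the source reports. "The series", "measured", "known", "first", "only" and "open" are said of these compounds alone.

Compound 2 `CC1(C)Cc2c(sc(NC(=O)c3cn[nH]c3)c2C(N)=O)C(C)(C)O1` stands highest of the three numbers shown in an assay on cells for positive allosteric modulation of Cystic fibrosis transmembrane conductance regulator variant F508del (Homo sapiens), with stated times of 10 min and 7 s, in the presence of a further agent that is not named here (on this read-out higher numbers stand for an effect only at larger amounts of compound and lower numbers for an effect already at smaller amounts), giving 125 nM. Compound 1 `CC1(C)Cc2c(sc(NC(=O)c3ccccc3O)c2C(N)=O)C(C)(C)O1` gives 4 nM, and compound 3 `CC1(C)Cc2c(sc(NC(=O)C3(CO)CC3)c2C(N)=O)C(C)(C)O1` gives 15 nM. The step of a 31-fold higher number from compound 1 to compound 2 (1.49 log units; beyond the scatter) is large; the step of an 8.3-fold lower number from compound 2 to compound 3 (0.92 log units; beyond the scatter) is modest, as is a 3.8-fold higher number from compound 1 to compound 3 (0.57 log units; beyond the scatter). Compound 4 `CC1(C)Cc2c(sc(NC(=O)[C@H](O)C(C)(C)C)c2C(N)=O)C(C)(C)O1` has not yet been measured. It differs from compound 2 by 1-hydroxy-2,2-dimethylpropyl in place of 1H-pyrazol-4-yl on a carbonyl carbon. Among the measured compounds shown here, the step bearing most on this change is the one from compound 2 to compound 3, where a ring-free group carrying a hydroxyl entered on the carbonyl carbon in place of the 1H-pyrazol-4-yl, and the number fell by a modest amount. Compound 4 also carries a ring-free group with a hydroxyl in that place, so a drop of similar size in this assay is expected, though the size is uncertain because only an 8.3-fold lower number from compound 2 to compound 3 (0.92 log units; beyond the scatter) speaks to it directly. Compound 4 is therefore estimated at 22 nM, with a range from 6 nM to 80 nM, which means an expected step of a 5.7-fold lower number from compound 2 to compound 4 (0.75 log units; beyond the scatter).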

Compound 4, half-maximal effective concentration: 127 nM
The estimate for compound 4 lay 5.8-fold (0.76 log units) below the measured number; the measured number lies above the stated range.
By their numbers in this assay, from the lowest: compound 1; then compound 3; then compounds 2 and 4 (each within the scatter of the next).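

In this assay, a hydroxyl on a ring-free group at this carbonyl carbon does not by itself bring the lower number seen with compound 3: a 1.0-fold higher number from compound 2 to compound 4 (0.01 log units; within the scatter), so 1-hydroxy-2,2-dimethylpropyl and 1H-pyrazol-4-yl cannot be told apart here. The two ring-free groups carrying a hydroxyl differ clearly from each other, with an 8.5-fold higher number from compound 3 to compound 4 (0.93 log units; beyond the scatter), so neither the hydroxyl nor the lack of a ring settles the outcome at this place, and 2-hydroxyphenyl keeps its lead, with a 32-fold higher number from compound 1 to compound 4 (1.50 log units; beyond the scatter). No measurement at hand accounts for these differences.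

The compounds shown leave open whether the opposite configuration at the stereocentre of 1-hydroxy-2,2-dimethylpropyl would change the number. They also leave open whether an amine in place of the hydroxyl of 1-(hydroxymethyl)cyclopropyl would keep the value of compound 3 at 15 nM.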